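The source may report more compounds than this note shows. Statements on the series, on what has been measured and on what is new or still open speak of the compounds shown alone.

Compound 1 `O=S(=O)(Nc1ccc(-c2nc3ccccc3o2)cc1)c1ccc(Cl)c(C(F)(F)F)c1`: 69000 nM
Compound 2 `Cc1ccc(S(=O)(=O)Nc2ccc(-c3nc4ccccc4o3)cc2)cc1`: 88000 nM
Compound 3 `O=S(=O)(Nc1ccc2oc(-c3ccccc3)nc2c1)c1ccc(Cl)c(Cl)c1`: 71000 nM

All three were tested in an ADME assay on HEK293 cells (Homo sapiens) for cytotoxicity, read by resazurin assay, with a stated time of 48 h; a lower number here means that less compound is tolerated, a higher number that more compound is tolerated. Compound 2 has the highest of the three numbers, but its gaps to compound 3 and to compound 1 both lie within the scatter, so no ranking among them can be claimed. Compound 4 `COc1cccc(S(=O)(=O)Nc2ccc(-c3nc4ccccc4o3)cc2)c1` has not yet been measured; it differs from compound 2 by 3-methoxyphenyl in place of 4-methylphenyl on a sulfonyl sulfur. Within the data shown here, no step between measured compounds shows what this change does. Since the three measured values sit so close together, the step is expected to stay within the scatter, with no direction favoured. For compound 4 the half-maximal cytotoxic concentration is estimated at 80000 nM, with a range from 40000 nM to 160000 nM. The step this estimate implies is expected to be a 1.1-fold lower number from compound 2 to compound 4 (0.04 log units; within the scatter).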

Compound 4, half-maximal cytotoxic concentration: > 100000 nM
Compound 4: a limit, no number; the forecaster's own chance of this, stated with the estimate: 25%; at least 1.2-fold (0.09 log units) between middle value and limit.
By their numbers in this assay, from the lowest: compounds 1, 3 and 2 (each within the scatter of the next). At a limit, above all of these: compound 4.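

Compound 4 gives > 100000 nM in this assay, which is a limit and not a number, and it alone stands there: the limit of > 100000 nM in this assay, at which 1 of the 4 values shown sits. The first step read at this place, 3-methoxyphenyl in place of 4-methylphenyl on a sulfonyl sulfur, is an at least 1.1-fold higher number from compound 2 to compound 4 (0.05 log units; that floor lies within the scatter), so the change brings no sign of lower tolerance, while its full size stays unread.

As far as these compounds go, whether the methoxy group or its place on the ring counts stays open, for this change alters both at once. The compounds shown also leave open what an amine or a carboxylic acid on that ring would do.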